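Alkyl chain and ring substituent in a rat oral read-out

The compounds below may be only part of what the source reports. "The series", "measured", "known", "first", "only" and "open" are said of these compounds alone.

Compound 1, `CC(C)c1ccc(-c2cc(Cl)cc(C(=O)Nc3nn[nH]n3)n2)cc1`: 68%
Compound 2, `CCCCc1ccc(-c2cc(Cl)cc(C(=O)Nc3nn[nH]n3)n2)cc1`: 83%
Compound 3, `Cc1cc(C(=O)Nc2nn[nH]n2)nc(-c2ccc(C(C)C)cc2)c1`: 100%

Of the compounds shown here, three have been measured in a functional assay on the whole organism with Rattus norvegicus as the target, at a dose of 3 mg/kg by the oral route (on this read-out lower numbers stand for a weaker effect and higher numbers for a stronger effect at the one dose given), and a fourth, compound 4, `CCCCc1ccc(-c2cc(C)cc(C(=O)Nc3nn[nH]n3)n2)cc1`, has not. Compound 1 carries an isopropyl group on the carbon-only ring and a chloro on the nitrogen-containing ring. Replacing the isopropyl by a butyl gives compound 2, a change counted as butyl in place of isopropyl on an aromatic carbon; in this assay the step was a number 15 percentage points higher from compound 1 to compound 2 (beyond the scatter). Replacing the chloro by a methyl gives compound 3, a change counted as methyl in place of chloro on an aromatic carbon; here the step was a number 32 percentage points higher from compound 1 to compound 3 (beyond the scatter), and compound 3 stands highest of the three measured compounds, beyond the scatter from both others.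

Compound 4 is related to compound 3 as compound 2 is to compound 1: the difference is butyl in place of isopropyl on an aromatic carbon, and the place line reads the same word for word, so this is the same change. The two cores differ by the chloro-to-methyl exchange already described. The earlier step was modest and upward from compound 1 to compound 2, but compound 3 already sits at the full read-out, leaving no room for a further rise. The step from compound 3 to compound 4 is therefore expected to be about a number 2 percentage points lower from compound 3 to compound 4 (within the scatter), resting on the upward step seen for compound 2 and the ceiling reached by compound 3.

Compound 4 is expected to give 98% in this assay. The estimate for compound 4 is expected to lie between 88% and 100%.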

Compound 4, a percentage reported as inhibition, in the whole organism at one dose (the size of the read-out at that dose, not a potency): 67%
The estimate for compound 4 lay 31 percentage points above the measured number; the whole stated range lies above it.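

In this assay, butyl in place of isopropyl on an aromatic carbon did not carry over from one core to the other, for on the core of compound 3 the step was a number 33 percentage points lower from compound 3 to compound 4 (beyond the scatter), opposite in direction to the earlier one: the same change on two cores in this assay, a number 15 percentage points higher (beyond the scatter) from compound 1 to compound 2 and a number 33 percentage points lower (beyond the scatter) from compound 3 to compound 4, 48 percentage points apart, beyond the scatter of two such steps. Methyl in place of chloro on an aromatic carbon reversed in the same way, the step on the butyl side of the series being a number 16 percentage points lower from compound 2 to compound 4 (beyond the scatter): the same change on two cores in this assay, a number 32 percentage points higher (beyond the scatter) from compound 1 to compound 3 and a number 16 percentage points lower (beyond the scatter) from compound 2 to compound 4, 48 percentage points apart, beyond the scatter of two such steps. These four compounds show that neither change can be transferred as a fixed increment, since the outcome of each depends on what sits at the other place, but they do not show why, and they rest on a single oral dose, a read-out of effect size rather than potency, in which compound 3 gives 100%.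

The compounds shown leave open whether the reversal belongs to butyl alone or would also appear with a propyl group or a longer chain such as hexyl on the carbon-only ring. They also leave open how an ethyl group or a methoxy group would behave in place of the methyl or chloro, and whether the pattern would hold at other doses.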